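Compound 2 to compound 3: butyl to ethyl

This account rests on a few compounds, and the source may have more. Where it says the series, first, only, none or still open, it means among the compounds named here.

Measured in a physicochemical assay for lipophilicity, in phosphate buffer, measured as octanol-water partition, at pH 11.5; a higher number here means a more lipophilic compound, a lower number a more polar compound:
compound 1 `CCOC(=N)NC(=N)Nc1ccc(Cl)cc1`: 2.32
compound 2 `CCCCNC(=N)NC(=N)Nc1ccc(Cl)cc1`: 3.13

Compound 2 holds the higher of the two numbers, at 3.13. Next in the series is compound 3 `CCNC(=N)NC(=N)Nc1ccc(Cl)cc1`, not yet measured. The structural change is hydrogen in place of ethyl on a saturated chain carbon, two bonds along the chain from an amine nitrogen, which also reads as butyl to ethyl.

Within the data shown here, no measured step shows this change on its own. Among the measured compounds shown here, the only measured step is a number 0.81 log units higher from compound 1 to compound 2 (beyond the scatter), with butylamino in place of ethoxy on a carbon with a double bond to nitrogen. That exchange is not the one at hand, so it bears on the new step only loosely, as a guide to size. The butylamino compound sits on the upper side of that step, so a step of similar modest size is expected in this assay, going downward. The expected change is a number 0.83 log units lower from compound 2 to compound 3 (beyond the scatter). For compound 3 the estimate is 2.3, with an expected range of 1.9 to 2.7.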

Compound 3, partition coefficient: 2.14
Compound 3: the middle estimate sits 0.16 log units above what was measured; the range from low to high includes it.
By their numbers in this assay, from the lowest: compounds 3 and 1 (each within the scatter of the next); then compound 2.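

In this assay, among these compounds, cutting butylamino back to ethylamino gives a number 0.99 log units lower from compound 2 to compound 3 (beyond the scatter), the first reading of this chain change on its own at this position. Ethylamino in place of ethoxy gives a number 0.18 log units lower from compound 1 to compound 3 (within the scatter), so with the two-carbon chain held, this exchange on the carbon with a double bond to nitrogen does not separate compound 1 from compound 3, whereas the earlier step, a number 0.81 log units higher from compound 1 to compound 2 (beyond the scatter), changed both the linking atom and the chain length; in these three compounds, the step beyond the scatter appears only where butylamino is present, and compound 2 alone stands apart from the other two. Nothing at hand explains why the number follows the chain in this way.

From the compounds shown here alone, two chain lengths on nitrogen fix no trend, so it remains open whether methylamino, a plain amino group or a longer chain such as hexylamino would fall on a single line with ethylamino and butylamino. Also open, going by these compounds, is whether butoxy would stand with butylamino as ethoxy stands with ethylamino, and whether a branched chain such as isopropylamino would read like its straight counterpart.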